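The compounds below may be only part of what the source reports. "The series", "measured", "known", "first", "only" and "open" are said of these compounds alone.

In a functional assay on PANC-1 cells (Homo sapiens) for inhibition, read by MTT assay, with a stated time of 24 h, tested at 10 uM (a lower number here means less inhibition, a higher number more inhibition at the concentration tested (going by the name of the read-out)), the measured compounds give these numbers:
compound 1 `CC(C)=CCC1Cc2c(OCc3ccccc3)cc(=O)n(CCCO)c2CC1(C)C`: 11.1%
compound 2 `CC(C)=CCC/C(C)=C/CC1Cc2c(OCc3ccccc3)cc(=O)n(CCCO)c2CC1(C)C`: 1.5%
compound 3 `CC(C)=CCC/C(C)=C/CC1Cc2c(OCCCNS(=O)(=O)c3ccc([N+](=O)[O-])cc3)cc(=O)n(CCCO)c2CC1(C)C`: 0%

On these numbers compound 2 sits between compound 1 and compound 3, and all three lie within the usual scatter of one another. Compound 4 `COc1ccc(OCCCOc2cc(=O)n(CCCO)c3c2CC(C/C=C(\C)CCC=C(C)C)C(C)(C)C3)cc1` differs from compound 2 by 2-(4-methoxyphenoxy)ethyl in place of phenyl on a saturated chain carbon bound to an oxygen on an aromatic ring. Going by the values given here, the only measured step, a number 9.6 percentage points lower from compound 1 to compound 2 (within the scatter), concerns a different part of the molecule and stayed within the scatter; no measured step touches the group on the aromatic oxygen, so nothing speaks for a shift beyond the scatter in either direction. Compound 4 is therefore expected to give about 3%, between 0% and 14%, an estimated step of a number 1.5 percentage points higher from compound 2 to compound 4 (within the scatter).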

Compound 4, a percentage reported as inhibition, at one concentration (the size of the read-out at that concentration, not a potency): 0%
For compound 4 the middle estimate is 3 percentage points above the measured one; the measured number falls inside the stated range.
By their numbers in this assay, from the lowest: compounds 3, 4, 2 and 1 (each within the scatter of the next, the first and the last beyond it).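

In this assay, placing 2-(4-methoxyphenoxy)ethyl instead of phenyl on the saturated chain carbon bound to an oxygen on an aromatic ring gives a number 1.5 percentage points lower from compound 2 to compound 4 (within the scatter). This first measured change at this position therefore shows that the larger group brings no gain in inhibition at the concentration tested. No available evidence bears on why the number moves so little. As far as these compounds go, with compound 2 and compound 4 both so low, it remains open whether any group here can raise inhibition. An amine or carboxylic acid at the end of this chain also remains untested in the compounds shown.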